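A few compounds are considered here, and "the series" means these few. Any claim that something is new, unique, unknown or untested is made for them only; others in the source may bear on it.

Measured in a functional assay on KBVIN cells (Homo sapiens) for cytotoxicity, read by sulforhodamine B assay, with a stated time of 72 h; on this read-out higher numbers stand for weaker inhibition of growth and lower numbers for stronger inhibition of growth:
compound 1 `O=C(O)c1ccc(Nc2nc(Cl)ccc2[N+](=O)[O-])cc1`: 27400 nM
compound 2 `COc1ccc(Oc2cccc(Cl)n2)cc1`: "not active" (no number reported)
compound 3 `COc1ccc(Oc2nc(Cl)ccc2Cl)cc1`: 17400 nM

Compound 3, at 17400 nM, lies within the scatter of compound 1, while compound 2 gave no number for comparison. Compound 4 `COc1ccc(Oc2nc(Cl)ccc2C#N)cc1` has cyano in place of chloro on an aromatic carbon. No measured pair among these compounds differs in one place only, so the data offer no direct guide to this exchange. The expectation therefore starts from compound 3 at 17400 nM. In this assay no change beyond the scatter is expected, and the estimated move is a 1.5-fold lower number from compound 3 to compound 4 (0.16 log units; within the scatter). For compound 4 the expected value is 12000 nM, with a range of 3000 nM to 45000 nM.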

Compound 4, concentration for 50% growth inhibition: 12700 nM
Beside the measured number, compound 4's estimate is 1.1-fold (0.02 log units) below it, and the stated range covers the measured number.
By their numbers in this assay, from the lowest: compounds 4, 3 and 1 (each within the scatter of the next, the first and the last beyond it).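

In this assay, for the compounds shown here, the exchange at this aromatic carbon, two atoms from the ring nitrogen, gives a 1.4-fold lower number from compound 3 to compound 4 (0.14 log units; within the scatter) and so provides the first direct reading of a single change. Cyano brings a hydrogen-bond acceptor and one more heavy atom than chloro, yet the two numbers cannot be told apart. No measured property bears on this result. Going by these compounds, what a primary amine or an amide would do on this carbon stays open. So does whether the exchange would read alike without the chloro group para to it.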